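The source may report more compounds than this note shows. Statements on the series, on what has been measured and on what is new or still open speak of the compounds shown alone.

Series notes, compound 4 pending.

The set rests on one shared core, read in a functional assay on the whole organism (strain Wister albino) for inhibition, with Rattus norvegicus as the target, read by paw edema, with stated times of 1 h and 4 h, at a dose of 50 mg/kg by the intraperitoneal route; on this read-out higher numbers stand for more inhibition at the one dose given (going by the name of the read-out) and lower numbers for less inhibition. Compound 1 `CN1C[C@@H](c2cccs2)[C@@]2(Cc3ccccc3C2=O)[C@@]12C(=O)Nc1ccccc12` gives 20% in this assay. Compound 2 `CN1C(=O)[C@@]2(c3ccccc31)N(C)C[C@@H](c1cccs1)[C@@]21Cc2ccccc2C1=O` gives 12.9% in this assay. Compound 3 `COc1ccc([C@@H]2CN(C)[C@]3(C(=O)N(C)c4ccccc43)[C@]23Cc2ccccc2C3=O)cc1` gives 3.8% in this assay, the lowest of the three numbers, though its gap to compound 2 lies within the scatter and only its gap to compound 1 lies beyond it.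

Two single changes connect the measured compounds. From compound 2 to compound 1 the change is hydrogen in place of methyl on an amide-type nitrogen in a ring, and it made a step of a number 7.1 percentage points higher from compound 2 to compound 1 (within the scatter). From compound 2 to compound 3 the cores differ by 4-methoxyphenyl in place of thiophen-2-yl on a saturated ring carbon, and that change made a step of a number 9.1 percentage points lower from compound 2 to compound 3 (within the scatter). Neither step rises above the scatter, so no order among the three is claimed here.

Compound 4 `COc1ccc([C@@H]2CN(C)[C@]3(C(=O)Nc4ccccc43)[C@]23Cc2ccccc2C3=O)cc1` is not yet measured. It differs from compound 3 by hydrogen in place of methyl on an amide-type nitrogen in a ring, the same change as from compound 2 to compound 1, with the place described in the same words. The earlier step was a number 7.1 percentage points higher from compound 2 to compound 1 (within the scatter). A step of about the same size is expected now, resting on that step and on the value 3.8% of compound 3. The expected step is a number 7.2 percentage points higher from compound 3 to compound 4 (within the scatter). Compound 4 is expected to give 11% in this assay, within a range of 0% to 24%, with the same caution that one prior step within the scatter is a thin basis.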

Compound 4, a percentage reported as inhibition, in the whole organism at one dose (the size of the read-out at that dose, not a potency): 21.8%
For compound 4 the middle estimate is 10.8 percentage points below the measured one; the range from low to high includes it.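

Among the compounds shown here, the change of hydrogen in place of methyl on an amide-type nitrogen in a ring points the same way on both cores in this assay, and the two steps cannot be told apart: the same change on two cores in this assay, a number 7.1 percentage points higher (within the scatter) from compound 2 to compound 1 and a number 18 percentage points higher (beyond the scatter) from compound 3 to compound 4, 10.9 percentage points apart, within the scatter of two such steps The change of 4-methoxyphenyl in place of thiophen-2-yl on a saturated ring carbon, now also read as a number 1.8 percentage points higher from compound 1 to compound 4 (within the scatter), likewise gives no sign that its step depends on the group on that nitrogen: the same change on two cores in this assay, a number 9.1 percentage points lower (within the scatter) from compound 2 to compound 3 and a number 1.8 percentage points higher (within the scatter) from compound 1 to compound 4, 10.9 percentage points apart, within the scatter of two such steps This supports carrying the hydrogen-for-methyl change between these two cores, but it does not show a general gain in inhibition: it rests on two pairs, and only a number 18 percentage points higher from compound 3 to compound 4 (beyond the scatter) stands clear of the scatter, while the earlier step does not.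

The compounds shown leave open whether a longer chain on the amide-type nitrogen, such as ethyl or benzyl, would read closer to methyl or to hydrogen. They also leave open how the series responds on the saturated ring carbon to groups other than thiophen-2-yl and 4-methoxyphenyl, such as an unsubstituted phenyl or a phenyl bearing a carboxylic acid or an amine.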